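Notes on the shared core: thiophenyl to benzyl

The source may report more compounds than this note shows. Statements on the series, on what has been measured and on what is new or still open speak of the compounds shown alone.

Compound 1 `Nc1cccc(-c2cn3nc(-c4cccs4)sc3n2)c1` carries thiophen-2-yl on the shared core and an aniline on the other side. In a functional assay on FM3A cells (Mus musculus) for inhibition, read by cell counting, with a stated time of 2 days (on this read-out higher numbers stand for weaker inhibition and lower numbers for stronger inhibition), compound 1 gives only a limit of the assay, > 250000 nM, and not a number. This places compound 1 at the limit of > 250000 nM in this assay, at which 1 of the 3 values shown sits, while the two other measured compounds return numbers. Compound 2 `CCc1ccc(-c2nn3cc(-c4cccc(N)c4)nc3s2)cc1` gives 8200 nM in this assay, and compound 3 `C=C(Br)C(=O)Nc1cccc(-c2cn3nc(-c4ccc(OCC)cc4)sc3n2)c1` gives 1100 nM in this assay. Among the measured compounds shown here, no two measured compounds differ in a single place, so no measured step is available, and the gap between compound 2 and compound 3 cannot be tied to one change.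

Compound 4 `Nc1cccc(-c2cn3nc(Cc4ccccc4)sc3n2)c1` is not yet measured. It differs from compound 1 as benzyl in place of thiophen-2-yl on an aromatic carbon. The thiophenyl of compound 1 sits at the limit, and the aryl of compound 2 gives a number, so a move down from the limit is expected, though only loosely. The expected step is an at least 4.1-fold lower number from compound 1 to compound 4 (0.61 log units; beyond the scatter), leaning on compound 2 with 8200 nM. For compound 4 the estimate is 60000 nM, with a range from 8000 nM to 250000 nM, and a real chance that only a limit is reported again.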

Compound 4, half-maximal inhibitory concentration: 4700 nM
Estimate against measurement, compound 4: 13-fold (1.11 log units) above; measured number below the stated range.
By their numbers in this assay, from the lowest: compound 3; then compounds 4 and 2 (each within the scatter of the next). At a limit, above all of these: compound 1.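

Benzyl in place of thiophen-2-yl gives the series its first measured step in one place: in this assay the change gives an at least 53-fold lower number from compound 1 to compound 4 (1.72 log units; beyond the scatter). This shows that the group on this aromatic carbon of the shared core matters, as this change alone takes the aniline-bearing compound from a limit to a number. The size of the step remains a lower bound, as compound 1 stands at a limit of the assay and not at a number: the limit of > 250000 nM in this assay, at which 1 of the 4 values shown sits.

As far as these compounds go, it remains open whether the step follows the carbon linking the ring to the core or the exchange of the five-membered aromatic ring for the six-membered one. Also open, from the compounds shown here alone, is how a longer chain to that ring, or an amine or a carboxylic acid on it, would read.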